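Ethoxy for methoxy on the hydroxyoxolane side chain

The source may hold more compounds than are shown below. What is called first, only, known or untested is meant among the compounds shown, and "the series" means these compounds.

Values in a functional assay on RAW264.7 cells (Mus musculus) for inhibition, read by Griess assay, with stated times of 2 h and 18 h (a higher number here means a weaker inhibitor, a lower number a stronger inhibitor), follow
- compound 1 `CC1=C(CCc2ccoc2)[C@@]2(C)CCCC(C)(C)[C@@H]2[C@H](O)C1=O` gives > 50000 nM as a limit
- compound 2 `CCOC1CC(O)(CCC2=C(C)C(=O)[C@@H](O)[C@H]3C(C)(C)[C@H](OC(C)=O)CC[C@]23C)CO1` gives 30400 nM as a number
- compound 3 `COC1CC(O)(CCC2=C(C)C(=O)[C@@H](O)[C@H]3C(C)(C)CCC[C@]23C)CO1` gives 26400 nM as a number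

Compound 3 at 26400 nM and compound 2 at 30400 nM lie within the scatter of each other. Compound 4 `CCOC1CC(O)(CCC2=C(C)C(=O)[C@@H](O)[C@H]3C(C)(C)CCC[C@]23C)CO1` differs from compound 3 by methyl in place of hydrogen on a saturated chain carbon bound to an oxygen on a saturated carbon in the change of methoxy to ethoxy. For the measured compounds named here, the one measured step on this group, an at least 1.8-fold lower number from compound 1 to compound 3 (0.27 log units; that floor lies within the scatter) in this assay as the side chain changes, does not test the alkoxy end. Compound 2 already carries ethoxy but differs from compound 3 elsewhere too. The expected change is a 1.0-fold higher number from compound 3 to compound 4 (0.01 log units; within the scatter) and so none beyond the scatter. Compound 4 is estimated at 27000 nM within an expected range of 14000 nM to 50000 nM in this read-out.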

Compound 4, half-maximal inhibitory concentration: > 50000 nM
Compound 4: no number, only a limit (the forecaster's own chance of this, stated with the estimate: 15%); middle value at least 1.8-fold (0.26 log units) away from the limit.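

In this assay compound 4 gives > 50000 nM, a limit and not a number. Methoxy to ethoxy gives an at least 1.8-fold higher number from compound 3 to compound 4 (0.27 log units; that floor lies within the scatter), and hydrogen in place of acetoxy on a saturated ring carbon gives an at least 1.6-fold higher number from compound 2 to compound 4 (0.21 log units; that floor lies within the scatter). Both floors lie within the scatter, and the step between the two limits of compound 1 and compound 4 cannot be read: the limit of > 50000 nM in this assay, at which 2 of the 4 values shown sit.

Going by these compounds, whether a propoxy group or an amine at this end of the side chain gives a number on the shared core stays open. On these data alone, the true size of both readable steps also stays open.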